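A few compounds are considered here, and "the series" means these few. Any claim that something is new, unique, unknown or untested is made for them only; others in the source may bear on it.

Measured compounds:
Compound 1 `CC(=O)Nc1ccc(/C=C/C(=O)c2ccc3c(c2O)C=CC(C)(C)O3)cc1`: 279000 nM
Compound 2 `CC1(C)C=Cc2c(ccc(C(=O)/C=C/c3ccc(F)c(F)c3)c2O)O1`: 146000 nM

Among the measured compounds shown here, in an ADME assay on Vero cells (Chlorocebus sabaeus) for cytotoxicity, read by MTT assay, with a stated time of 72 h (a lower number here means that less compound is tolerated, a higher number that more compound is tolerated), compound 2 gives 146000 nM and lies within the scatter of compound 1, the only other measured compound. Compound 3 `CC1(C)C=Cc2c(ccc(C(=O)/C=C/c3ccc(C#N)cc3)c2O)O1` carries 4-cyanophenyl in place of 3,4-difluorophenyl on a double-bonded chain carbon bound to a double-bonded chain carbon. For the measured compounds named here, no step between measured compounds shows what such an exchange does, so no change beyond the scatter is expected in this assay. The expected outcome is a 1.2-fold higher number from compound 2 to compound 3 (0.07 log units; within the scatter), taking compound 2 at 146000 nM as the starting point. For compound 3 the estimated value is 170000 nM, within an expected range of 60000 nM to 400000 nM.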

Compound 3, half-maximal cytotoxic concentration: 80200 nM
For compound 3 the middle estimate is 2.1-fold (0.33 log units) above the measured one; the range from low to high includes it.
By their numbers in this assay, from the lowest: compounds 3, 2 and 1 (each within the scatter of the next, the first and the last beyond it).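

In this assay, 4-cyanophenyl in place of 3,4-difluorophenyl on a double-bonded chain carbon bound to a double-bonded chain carbon gives a step that stays within the scatter (a 1.8-fold lower number from compound 2 to compound 3 (0.26 log units; within the scatter)). Cyano in place of acetamido on an aromatic carbon gives the one step here that passes beyond it (a 3.5-fold lower number from compound 1 to compound 3 (0.54 log units; beyond the scatter)), so at that aromatic carbon the exchange of group does change how much compound is tolerated. As far as these compounds go, what an amine or a carboxylic acid on that aromatic carbon would do remains open. Nothing measured here explains either step.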